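The compounds below may be only part of what the source reports. "The series", "measured", "known", "first", "only" and "open" are said of these compounds alone.

Measured in a functional assay on HT-29 cells (Homo sapiens) for cytotoxicity, read by MTT assay, with a stated time of 72 h; a lower number here means a stronger inhibitor, a higher number a weaker inhibitor:
- compound 1 `Cc1ccccc1NC(=O)CN1CCN(c2nnc(Cc3ccccc3)c3ccccc23)CC1`: 113000 nM
- compound 2 `O=C(CN1CCN(c2nnc(Cc3ccncc3)c3ccccc23)CC1)Nc1c(F)cccc1F`: 28700 nM
- compound 3 `Cc1ccccc1NC(=O)CN1CCN(c2nnc(Cc3ccncc3)c3ccccc23)CC1`: 15000 nM

Compound 1 holds the highest number of the three. Compound 4 `O=C(CN1CCN(c2nnc(Cc3ccccc3)c3ccccc23)CC1)Nc1ccc(F)c(Cl)c1` keeps the core of compound 1 and puts 3-chloro-4-fluorophenyl in place of 2-methylphenyl on an amide-type nitrogen. Among the compounds with values here, only one measured step changes the group at that place, a 1.9-fold lower number from compound 2 to compound 3 (0.28 log units; within the scatter), and it stays within the scatter, although it involves different groups. The larger step, a 7.5-fold lower number from compound 1 to compound 3 (0.88 log units; beyond the scatter), swaps phenyl for pyridin-4-yl elsewhere and leaves this group untouched. No step beyond the scatter is therefore expected in this assay, and any shift is expected to be small and towards a lower number. The expected change is a 1.4-fold lower number from compound 1 to compound 4 (0.15 log units; within the scatter). For compound 4 the estimate is 80000 nM, with an expected range from 30000 nM to 200000 nM.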

Compound 4, half-maximal inhibitory concentration: 13300 nM
For compound 4 the middle estimate is 6.0-fold (0.78 log units) above the measured one, and the stated range ends above it.
By their numbers in this assay, from the lowest: compounds 4, 3 and 2 (each within the scatter of the next, the first and the last beyond it); then compound 1.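

In this assay, 3-chloro-4-fluorophenyl on the amide-type nitrogen gives an 8.5-fold lower number from compound 1 to compound 4 (0.93 log units; beyond the scatter). Within the data shown here, the only earlier step at this place, a 1.9-fold lower number from compound 2 to compound 3 (0.28 log units; within the scatter), stayed within the scatter, so this result is the first to show that a change here can move the number beyond it, and it does so with the phenyl group of compound 1 retained. Nothing available explains the size of this step. Going by these compounds, it remains open whether the chlorine or the fluorine accounts for the step, or whether both are needed. Also open, on these data alone, is how a cyclohexyl group on the amide-type nitrogen would compare.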